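The source may hold more compounds than are shown below. What is called first, only, known or untested is meant among the compounds shown, and "the series" means these compounds.

Measured in an in vitro functional assay on cells for antagonist activity at B1 bradykinin receptor (Homo sapiens), read by luminescence and calcium flux, with a stated time of 2 h; on this read-out higher numbers stand for weaker inhibition and lower numbers for stronger inhibition:
compound 1 `Cc1ccc(S(=O)(=O)N2C=CNC(=O)[C@H]2CC(=O)N[C@H]2CCN(C)CC2(C)C)cc1`: 0.42 nM
compound 2 `Cc1cc(S(=O)(=O)N2C=CNC(=O)[C@H]2CC(=O)N[C@H]2CCNCC2(C)C)c(C)cc1Cl`: 0.31 nM
compound 3 `Cc1cc(S(=O)(=O)N2C=CNC(=O)[C@H]2CC(=O)N[C@H]2CCN(C)CC2(C)C)c(C)cc1Cl`: 0.28 nM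

Compound 3 carries the lowest of the three numbers, but its gaps to the others, a 1.1-fold lower number from compound 2 to compound 3 (0.04 log units; within the scatter) and a 1.5-fold lower number from compound 1 to compound 3 (0.18 log units; within the scatter), both sit within the scatter, so no order among the three is established.

Compound 4 `Cc1cc(S(=O)(=O)N2C=CNC(=O)[C@H]2CC(=O)N2CC[C@H](N3CCCC3)C2)c(C)cc1Cl` differs from compound 3 by a group of 10 heavy atoms (8 carbon, 2 nitrogen; 2 five-membered non-aromatic rings with 1 hetero atom each) in place of a group of 10 heavy atoms (8 carbon, 2 nitrogen; one six-membered non-aromatic ring with 1 hetero atom), on a carbonyl carbon. Neither measured step touches this part of the molecule: one swaps the aryl on the sulfonyl sulfur, the other a methyl on the ring amine nitrogen, and both stayed within the scatter. The present change replaces the whole amide-side group, so a larger move is possible, with direction unknown; an estimated step of a 3.6-fold higher number from compound 3 to compound 4 (0.55 log units; beyond the scatter), toward a weaker number, is assumed. Compound 4 is therefore expected near 1 nM, within 0.3 nM to 4 nM.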

Compound 4, half-maximal inhibitory concentration: 19 nM
For compound 4 the middle estimate is 19-fold (1.28 log units) below the measured one; the whole stated range lies below it.
By their numbers in this assay, from the lowest: compounds 3, 2 and 1 (each within the scatter of the next); then compound 4.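

Among these compounds, on a carbonyl carbon, the amide-side group gives the first steps beyond the scatter: in this assay the group with 2 five-membered non-aromatic rings gives a 68-fold higher number from compound 3 to compound 4 (1.83 log units; beyond the scatter) and also a 61-fold higher number from compound 2 to compound 4 (1.79 log units; beyond the scatter) when it enters. Unlike the aryl and ring-amine methyl changes, this swap alters the ring count and takes the hydrogen-bond donors from 1 to 0. No evidence on the cause of these steps is at hand.

Ring size and donor count change together here, so neither can be singled out. A piperazine or an open-chain amine on the same carbonyl carbon remains an open case.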